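This account rests on a few compounds, and the source may have more. Where it says the series, first, only, none or still open, it means among the compounds named here.

Measured so far:
compound 1, `COc1ccc(S(=O)(=O)NCCCN2CCN(c3cccc(C(F)(F)F)c3)CC2)cc1`: 89 nM
compound 2, `COc1ccc(S(=O)(=O)NCCCN2CCN(c3ccccc3)CC2)cc1`: > 10000 nM
compound 3, `COc1ccc(S(=O)(=O)NC(C)CCN2CCN(c3cccc(C(F)(F)F)c3)CC2)cc1`: 107 nM

In an assay on CHO cells for displacement of a labelled ligand from 5-hydroxytryptamine receptor 7 (Homo sapiens) (a higher number here means a weaker inhibitor, a lower number a stronger inhibitor), compound 1 gives 89 nM and compound 3 gives 107 nM. The two lie within the scatter of each other (a 1.2-fold higher number from compound 1 to compound 3 (0.08 log units; within the scatter)), so the methyl on the chain carbon makes no step beyond the scatter. For compound 2 the value > 10000 nM is a limit of this assay, not a number (the limit of > 10000 nM in this assay, at which 1 of the 3 values shown sits). Compound 3 therefore stands with compound 1 among the two numbers shown, while compound 2 sits at the limit.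

Compound 4, `COc1ccc(S(=O)(=O)NC(C)CCN2CCN(c3ccccc3)CC2)cc1`, differs from compound 3 in one place: hydrogen in place of trifluoromethyl on an aromatic carbon. The same change has been measured once in this series, and there it was large: an at least 110-fold higher number from compound 1 to compound 2 (2.05 log units; beyond the scatter). Since the chain methyl that separates compound 3 from compound 1 gave no step beyond the scatter, the change to compound 4 is expected to behave as the change to compound 2 did, with a large rise in this assay and a good chance that only a limit is reported again.

Compound 4 is expected at 12000 nM, within a range of 3000 nM to 40000 nM. The expected step is a 110-fold higher number from compound 3 to compound 4 (2.05 log units; beyond the scatter).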

Compound 4, half-maximal inhibitory concentration: 377 nM
Compound 4: middle estimate off by 32-fold (1.50 log units), on the high side, and the stated range ends above it.
By their numbers in this assay, from the lowest: compounds 1 and 3 (each within the scatter of the next); then compound 4. At a limit, above all of these: compound 2.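

In this assay, the change from 3-(trifluoromethyl)phenyl to phenyl does not carry a fixed cost across the series: with the chain methyl present it gives a 3.5-fold higher number from compound 3 to compound 4 (0.55 log units; beyond the scatter), and the step on the core of compound 1 is far larger: the same change on two cores in this assay, an at least 110-fold higher number (2.05 log units; beyond the scatter) from compound 1 to compound 2 and a 3.5-fold higher number (0.55 log units; beyond the scatter) from compound 3 to compound 4, at least 31-fold (1.50 log units) apart, beyond the scatter of two such steps For compound 2, > 10000 nM is a limit of the assay, not a number. The chain methyl, which makes no step beyond the scatter while trifluoromethyl is on the aromatic ring, does make one on the plain phenyl, an at least 26-fold lower number from compound 2 to compound 4 (1.42 log units; beyond the scatter), so the two changes cannot be read independently of each other: the same change on two cores in this assay, a 1.2-fold higher number (0.08 log units; within the scatter) from compound 1 to compound 3 and an at least 26-fold lower number (1.42 log units; beyond the scatter) from compound 2 to compound 4, at least 31-fold (1.50 log units) apart, beyond the scatter of two such steps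

On these data alone, this dependence rests on a single set of four compounds, so it remains open whether a chlorine or a nitrile in place of trifluoromethyl, or an ethyl in place of the chain methyl, would show the same behaviour. As far as these compounds go, the full size of the step from compound 1 to compound 2, and with it the full size of the gap between the two steps, also remains open, as only a bound on each can be read.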